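A few compounds are considered here, and "the series" means these few. Any claim that something is new, unique, unknown or untested is made for them only; others in the source may bear on it.

Compound 1, `CCCNc1nc(C#Cc2ccc(F)s2)nc2c1ncn2[C@H]1[C@H](O)[C@H](O)[C@]2(C(=O)NC)C[C@H]12`, gives 1.13 nM in an assay on CHO cells for displacement of a labelled ligand from adenosine receptor A3 (Homo sapiens); a higher number here means a weaker inhibitor, a lower number a stronger inhibitor. Compound 2, `CNC(=O)[C@H]1O[C@@H](n2cnc3c(NC)nc(C#Cc4ccc(F)s4)nc32)[C@H](O)[C@@H]1O`, gives 2.3 nM in this assay.

Of the two measured compounds, compound 2 stands with the higher number; compound 1 lies lower by a gap beyond the usual scatter. Within the data shown here, the two differ in more than one place, so no single step links them, and their values are reported only as they stand.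

Compound 3, `CCCNc1nc(C#Cc2ccc(F)s2)nc2c1ncn2[C@@H]1O[C@H](C(=O)NC)[C@@H](O)[C@H]1O`, is the next compound to be measured. It differs from compound 2 by ethyl in place of hydrogen on a saturated chain carbon bound to a nitrogen on an aromatic ring, which reads as methylamino to propylamino. Nothing measured isolates this change. A modest shift toward a lower number is expected, a 1.5-fold lower number from compound 2 to compound 3 (0.19 log units; within the scatter), though it may not exceed the scatter. Compound 3 is expected to give 1.5 nM in this assay, within a range from 0.5 nM to 5 nM.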

Compound 3, inhibition constant: 8.51 nM
The estimate for compound 3 lay 5.7-fold (0.75 log units) below the measured number, and the stated range ends below it.
By their numbers in this assay, from the lowest: compound 1; then compound 2; then compound 3.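

Read on the shared core in this assay, the change from methylamino to propylamino gives a 3.7-fold higher number from compound 2 to compound 3 (0.57 log units; beyond the scatter), the first direct reading of this change in the series. At this position, then, ethyl in place of hydrogen on a saturated chain carbon bound to a nitrogen on an aromatic ring weakens inhibition rather than leaving it unchanged or improving it, though this rests on a single pair. Nothing available explains why the longer chain gives the higher number.

Going by these compounds, whether an ethylamino group, a branched isopropylamino group or a plain amine at this place would give a number nearer that of compound 2 or of compound 3 remains open. Also open, on these data alone, is whether the same change would have a step of similar size on the core of compound 1.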